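Hydroxy on a chain already at the limit

The source may report more compounds than this note shows. Statements on the series, on what has been measured and on what is new or still open speak of the compounds shown alone.

In a functional assay on NCI-H460 cells (Homo sapiens) for cytotoxicity, read by MTT assay (a higher number here means a weaker inhibitor, a lower number a stronger inhibitor), compound 1 (`Cc1c(O)cc(CCCCC(C)C)oc1=O`) gives > 200000 nM, which is a limit and not a number. Compound 2 (`Cc1c(O)cc(CCCCC(C)(C)O)oc1=O`) gives > 200000 nM, again a limit. Compound 3 (`CCC(C)CCCCc1cc(O)c(C)c(=O)o1`) gives > 200000 nM, also a limit. Compound 3 therefore has no number of its own, and the series offers only (the limit of > 200000 nM in this assay, at which 3 of the 3 values shown sit).

Compound 4 (`Cc1c(O)cc(CCCCC(C)[C@H](C)O)oc1=O`) differs from compound 3 in one place, (hydroxy in place of hydrogen on a saturated chain carbon bound to two saturated chain carbons), so that sec-butyl becomes 2-hydroxy-1-methylpropyl. Within the data shown here, the closest precedent is compound 2, where hydroxy also replaces hydrogen, though on a saturated chain carbon bound to three saturated chain carbons: a step that the two limits leave unreadable from compound 1 to compound 2. The two remaining chain changes, a step that the two limits leave unreadable from compound 1 to compound 3 and a step that the two limits leave unreadable from compound 2 to compound 3, give no measured size either. Among the measured compounds shown here, no measured step therefore points in a direction, and none of the three compounds has left the limit. The expected result is a number no higher from compound 3 to compound 4 (the limit leaves the size open), with no shift beyond the scatter in either direction, and compound 4 is expected most probably to be reported as a limit as well. For compound 4 the estimated value is 200000 nM, with an expected range from 80000 nM to 400000 nM.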

Compound 4, half-maximal inhibitory concentration: > 200000 nM
Compound 4: no number, only a limit; the forecaster's own chance of this, stated with the estimate: 80%; the middle value sits exactly at the limit.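

Compound 4 gives > 200000 nM, which is a limit and not a number. Its steps from compound 1, compound 2 and compound 3 therefore cannot be read, and the series stays where it stood: the limit of > 200000 nM in this assay, at which 4 of the 4 values shown sit.

The compounds shown leave open whether any of these chain changes shifts the result in this assay at all, since none of them has a numerical value there.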